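Swapping a ring for a short amide on compound 2

The source may report more compounds than this note shows. Statements on the series, on what has been measured and on what is new or still open speak of the compounds shown alone.

Measured compounds:
- Compound 1, `Cn1ncc(Cl)c1-c1cc(C(=O)NC2CNCC2c2ccc(C(F)(F)F)cc2)oc1Cl`, in an assay for inhibition of RAC-alpha serine/threonine-protein kinase (Homo sapiens), read by HTRF, with a stated time of 1 h (on this read-out lower numbers stand for stronger inhibition and higher numbers for weaker inhibition), gives 538 nM.
- Compound 2, `Cn1ncc(Cl)c1-c1cc(C(=O)N[C@@H]2CN[C@H](CCN3CCC(O)CC3)C[C@H]2c2ccc(Cl)c(Cl)c2)oc1Cl`, in this assay gives 5.99 nM.

Compound 2 stands at the lower of the two numbers, and the gap to compound 1 is beyond the scatter of repeated measurements, so compound 2 is the stronger inhibitor of the pair. The two compounds differ in several places at once, so no single change can be read from that gap.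

The next compound, compound 3, `Cn1ncc(Cl)c1-c1cc(C(=O)N[C@@H]2CN[C@H](CC(=O)NCCO)C[C@H]2c2ccc(Cl)c(Cl)c2)oc1Cl`, keeps the shared core and the dichlorophenyl group of compound 2 and alters one side chain: (2-hydroxyethyl)carbamoyl in place of (4-hydroxypiperidin-1-yl)methyl on a saturated chain carbon bound to a saturated ring carbon. The group that leaves carries one ring; the group that enters carries none and brings one more hydrogen-bond donor.

Within the data shown here, no measured pair shows this kind of exchange, so the expectation rests on compound 2 alone. Because compound 2 gives 5.99 nM, compound 3 is expected to stay in the same region, with a modest loss of potency thought more likely than a gain. The step from compound 2 to compound 3 is expected to be a 2.5-fold higher number from compound 2 to compound 3 (0.40 log units; beyond the scatter). Compound 3 is therefore estimated at 15 nM, within a range from 4 nM to 60 nM.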

Compound 3, half-maximal inhibitory concentration: 1.41 nM
For compound 3 the middle estimate is 11-fold (1.03 log units) above the measured one; measured number outside the range, below it.
By their numbers in this assay, from the lowest: compound 3; then compound 2; then compound 1.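

In this assay, replacing (4-hydroxypiperidin-1-yl)methyl with (2-hydroxyethyl)carbamoyl gives a 4.2-fold lower number from compound 2 to compound 3 (0.63 log units; beyond the scatter) and so improves inhibition. For this pair, the ring of the group that leaves is therefore not needed for a low number, since the group that enters has no ring and fewer heavy atoms. Nothing available here explains the size or direction of this step, so it stands only as an observation.

The loss of the ring, the arrival of the carbonyl and the addition of a hydrogen-bond donor all happen in this one step, and a single pair cannot show which of them matters or whether they matter only in combination. On these data alone, how a carboxylic acid, a simple amine or a longer chain ending in the same hydroxyl would behave at this place remains open, as does whether the step would hold on a different core.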